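The compounds below may be only part of what the source reports. "The series", "measured", "known", "first", "only" and "open" are said of these compounds alone.

Compound 1 `CNc1ncnc2c1c(-c1ccsc1)cn2[C@@H]1O[C@H](CO)[C@@H](O)[C@H]1O` gives > 20000 nM in a functional assay on K562 cells (Homo sapiens), read by MTT assay, with a stated time of 72 h (a lower number here means a stronger inhibitor, a higher number a weaker inhibitor), a limit of the assay.
Compound 2 `O=c1[nH]cnc2c1c(-c1cccs1)cn2[C@@H]1O[C@H](CO)[C@@H](O)[C@H]1O` gives > 20000 nM in this assay, likewise a limit.
Compound 3 `COc1ncnc2c1c(-c1ccsc1)cn2[C@@H]1O[C@H](CO)[C@@H](O)[C@H]1O` gives 90 nM in this assay.

Compound 1 thus stands at the limit of > 20000 nM in this assay, at which 2 of the 3 values shown sit, and carries no number of its own. For the measured compounds named here, the one measured step, an at least 220-fold lower number from compound 1 to compound 3 (2.34 log units; beyond the scatter), concerns the methylamino group, which compound 4 `CNc1ncnc2c1c(-c1cc3ccccc3o1)cn2[C@@H]1O[C@H](CO)[C@@H](O)[C@H]1O` keeps unchanged; no measured step touches the thiophen-3-yl group. Compound 4 differs from compound 1 by 1-benzofuran-2-yl in place of thiophen-3-yl on an aromatic carbon. Going by the values given here, with no step bearing on this change, compound 4 is expected to stay close to compound 1. The step of a number no higher from compound 1 to compound 4 (the limit leaves the size open) is therefore expected to be none beyond the scatter. Compound 4 is estimated at 20000 nM in this assay, with a range from 2000 nM to 100000 nM, and will most likely again be reported only as a limit.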

Compound 4, half-maximal inhibitory concentration: > 20000 nM
Compound 4: only a limit was reported; the forecaster's own chance of this, stated with the estimate: 70%; the middle value lies on the limit itself.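

For the compounds shown here, compound 1 and compound 4 both end at a limit of the assay, so no step between them can be read: the limit of > 20000 nM in this assay, at which 3 of the 4 values shown sit.
The compounds shown leave open how 1-benzofuran-2-yl compares with thiophen-3-yl when methoxy stands in place of methylamino.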